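The source may report more compounds than this note shows. Statements on the series, on what has been measured and on what is new or still open speak of the compounds shown alone.

Among the measured compounds shown here, compound 3 `CCCCc1nc2ccc(OC3CCN(C(C)=N)CC3)cc2n1Cc1ccc2ccc(C(=N)N)cc2c1` stands second highest among the three numbers measured so far in an assay on isolated protein for inhibition of serine protease 1 (Bos taurus); a higher number here means a weaker inhibitor, a lower number a stronger inhibitor. Compound 3 gives 5.7 nM. Its nearest neighbour is compound 2 `CC(=N)N1CCC(Oc2ccc3nc(CCC(N)=O)n(Cc4ccc5ccc(C(=N)N)cc5c4)c3c2)CC1`, which gives 4.4 nM; these two values lie within the scatter of each other. Furthest away is compound 1 `CC(=N)N1CCC(Oc2ccc3c(c2)nc(CCC(=O)O)n3Cc2ccc3ccc(C(=N)N)cc3c2)CC1`, which gives 14 nM, a number beyond the scatter from that of compound 3. For the measured compounds named here, compound 1 and compound 2 share the same core, and only their two values can be compared, since no single step between them is given here.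

Compound 4 `CCc1nc2ccc(OC3CCN(C(C)=N)CC3)cc2n1Cc1ccc2ccc(C(=N)N)cc2c1` differs from compound 3 by hydrogen in place of ethyl on a saturated chain carbon, two bonds along the chain from an aromatic carbon. Going by the values given here, the one measured step at the same place is a 1.3-fold higher number from compound 2 to compound 3 (0.11 log units; within the scatter), where ethyl took the place of carbamoyl and the number stayed within the scatter. Among the compounds with values here, that comparison suggests the group at this place can be exchanged without a large effect, although only one such comparison exists, and taking the ethyl away altogether is a different kind of change. The expectation is therefore a step of modest size, leaning towards a somewhat higher number, as expressed by a 1.8-fold higher number from compound 3 to compound 4 (0.24 log units; within the scatter). Compound 4 is expected to give 10 nM, with a range from 4 nM to 25 nM.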

Compound 4, inhibition constant: 7.7 nM
Estimate against measurement, compound 4: 1.3-fold (0.11 log units) above; the measured number falls inside the stated range.
By their numbers in this assay, from the lowest: compounds 2, 3, 4 and 1 (each within the scatter of the next, the first and the last beyond it).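

In this assay, cutting the butyl chain down to ethyl gives only a small step (a 1.4-fold higher number from compound 3 to compound 4 (0.13 log units; within the scatter)), so these two chain lengths cannot be told apart at this position. Taking the carbamoyl off the chain, leaving a plain ethyl, also gives a step inside the usual noise (a 1.8-fold higher number from compound 2 to compound 4 (0.24 log units; within the scatter)), which shows that a number in this range does not depend on the carbamoyl, and that an end group and a simple hydrocarbon chain can both sit here. No independent measurement is available to explain this tolerance.

Among the compounds shown here, the chains compared in one step so far are butyl, ethyl and the one ending in carbamoyl, so it remains open whether the tolerance extends to something as short as methyl, to a much longer chain such as octyl, or to a chain ending in an amine. Going by these compounds, how these same chains behave on any other protease also stays open, and that would matter for judging whether a change at this position is worth making.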